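The source may report more compounds than this note shows. Statements on the series, on what has been measured and on what is new or still open speak of the compounds shown alone.

Within the data shown here, compound 1 `COc1cccc2cc(C(=O)NC3CCCC3)c(=N)oc12` has been measured in an assay on HEK293 cells for displacement of a labelled ligand from adenosine receptor A2b (Homo sapiens), read by scintillation counting, with a stated time of 30 min, tested at 10 uM (a lower number here means less inhibition, a higher number more inhibition at the concentration tested (going by the name of the read-out)), where compound 1 gives 47%, the highest of the two numbers known here. Compound 2 `CCC(CO)NC(=O)c1cc2cc(Cl)ccc2oc1=N` gives 9% in this assay, a value that lies well beyond the scatter below that of compound 1. Compound 3 `COc1cccc2cc(C(=O)NC(CO)(CO)CO)c(=N)oc12` has not yet been measured. It differs from compound 1 in a single place: 2-hydroxy-1,1-bis(hydroxymethyl)ethyl in place of cyclopentyl on an amide-type nitrogen. Among the measured compounds shown here, no step between two measured compounds that differ in just one place is known, so the expectation rests on this structural change alone. A group carrying hydrogen-bond donors and acceptors replaces one that carries none, and a step downward, beyond the scatter, is expected, so that a number 27 percentage points lower from compound 1 to compound 3 (beyond the scatter). Compound 3 is accordingly estimated at 20%, with a likely range from 5% to 40%.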

Compound 3, a percentage reported as inhibition, at one concentration (the size of the read-out at that concentration, not a potency): 28%
Estimate against measurement, compound 3: 8 percentage points below; the range from low to high includes it.
By their numbers in this assay, from the lowest: compound 2; then compound 3; then compound 1.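

Replacing cyclopentyl with 2-hydroxy-1,1-bis(hydroxymethyl)ethyl on the amide-type nitrogen gives, in this assay, a number 19 percentage points lower from compound 1 to compound 3 (beyond the scatter), the first step shown in which only one group changes, so the group on this nitrogen does affect the result. The inhibition does not vanish with the ring gone and hydrogen-bond donors and acceptors added, as compound 3 still gives 28% at the concentration tested. No measurement at hand explains this step.

The compounds shown do not separate the loss of the ring from the arrival of the hydroxyl groups. Going by these compounds, whether a cyclohexyl ring, a tert-butyl group or a chain ending in an amine on the same nitrogen would keep, lower or raise the inhibition remains open.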